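Bromo for Fluoro on the Indole of Compound 3

The source may hold more compounds than are shown below. What is called first, only, known or untested is meant among the compounds shown, and "the series" means these compounds.

Compound 1 `CO[C@@H]1[C@H](N(C)c2ncc(-c3c[nH]c4ccc(F)cc34)s2)C[C@H]2O[C@]1(C)n1c3ccccc3c3c4c(c5c6ccccc6n2c5c31)C(=O)NC4`: > 10000 nM
Compound 2 `CO[C@@H]1[C@H](N(C)c2ncc(-c3c[nH]c4ccccc34)s2)C[C@H]2O[C@]1(C)n1c3ccccc3c3c4c(c5c6cc(Br)ccc6n2c5c31)C(=O)NC4`: > 10000 nM
Compound 3 `CO[C@@H]1[C@H](N(C)c2ncc(-c3c[nH]c4ccc(F)cc34)s2)C[C@H]2O[C@]1(C)n1c3ccccc3c3c4c(c5c6cc(Br)ccc6n2c5c31)C(=O)NC4`: > 10000 nM

In a functional assay on K562 cells (Homo sapiens) for antiproliferative activity, read by CellTiter-Glo, with a stated time of 72 h (a higher number here means a weaker inhibitor, a lower number a stronger inhibitor), compound 3 gives > 10000 nM, which is a limit of the assay and not a number. The same holds for compound 1, which gives > 10000 nM in this assay. Compound 2 likewise gives > 10000 nM in this assay, again a limit. The two single-change steps that reach compound 3, a step that the two limits leave unreadable from compound 1 to compound 3 and a step that the two limits leave unreadable from compound 2 to compound 3, cannot be read because of the limit of > 10000 nM in this assay, at which 3 of the 3 values shown sit.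

Compound 4 `CO[C@@H]1[C@H](N(C)c2ncc(-c3c[nH]c4ccc(Br)cc34)s2)C[C@H]2O[C@]1(C)n1c3ccccc3c3c4c(c5c6cc(Br)ccc6n2c5c31)C(=O)NC4` differs from compound 3 by bromo in place of fluoro on an aromatic carbon. Going by the values given here, no measured step speaks to this change, and every value shown sits at the limit. The estimated step is therefore a step that the limit leaves unreadable from compound 3 to compound 4, nothing beyond the scatter. Compound 4 is expected to give about 15000 nM, within a range from 7000 nM to 40000 nM, most likely reported again only as a limit.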

Compound 4, half-maximal inhibitory concentration: > 10000 nM
Compound 4: a limit, no number; the forecaster's own chance of this, stated with the estimate: 85%; the middle value lies beyond the limit too.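

In this assay compound 4 gives > 10000 nM, again a limit and not a number. The steps to compound 4 from compound 2 and compound 3 cannot be read: the limit of > 10000 nM in this assay, at which 4 of the 4 values shown sit. The compounds shown leave open whether these bromo and fluoro changes affect antiproliferative activity at all.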